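Cyclopropyl to 4-methylphenyl on the triazole of a shared core

The source may hold more compounds than are shown below. What is called first, only, known or untested is meant among the compounds shown, and "the series" means these compounds.

Compound 1, `O=C1O[C@H]([C@@H](O)Cn2cc(-c3cccc(O)c3)nn2)C(OCc2ccccc2)=C1OCc1ccccc1`: 59900 nM
Compound 2, `CCCCc1cn(C[C@H](O)[C@H]2OC(=O)C(OCc3ccccc3)=C2OCc2ccccc2)nn1`: 28600 nM
Compound 3, `O=C1O[C@H]([C@@H](O)Cn2cc(C3CC3)nn2)C(OCc2ccccc2)=C1OCc1ccccc1`: 43900 nM

Of the compounds shown here, three built on one shared core have been measured in a functional assay on A549 cells (Homo sapiens) for antiproliferative activity, read by MTT assay, with a stated time of 72 h; a lower number here means a stronger inhibitor, a higher number a weaker inhibitor. Compound 3 stands second highest of the three numbers. Its nearest neighbour is compound 1, separated by a 1.4-fold lower number from compound 1 to compound 3 (0.13 log units; within the scatter), and its furthest is compound 2, separated by a 1.5-fold higher number from compound 2 to compound 3 (0.19 log units; within the scatter). Between the other two the step is a 2.1-fold lower number from compound 1 to compound 2 (0.32 log units; beyond the scatter), the only one of the three that reaches beyond the scatter.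

Compound 4, `Cc1ccc(-c2cn(C[C@H](O)[C@H]3OC(=O)C(OCc4ccccc4)=C3OCc3ccccc3)nn2)cc1`, differs from compound 3 in a single place: 4-methylphenyl in place of cyclopropyl on an aromatic carbon. Among the measured compounds shown here, the measured step that bears most directly on this change is the one from compound 1 to compound 3, a 1.4-fold lower number from compound 1 to compound 3 (0.13 log units; within the scatter), in which 3-hydroxyphenyl at this position gave way to cyclopropyl with no difference beyond the scatter. Going back from cyclopropyl to a six-membered aromatic ring, here 4-methylphenyl, is therefore expected to move the number only a little, if at all, and no clear direction can be read from the three compounds measured. Compound 4 is estimated at 50000 nM, within a range of 20000 nM to 120000 nM. That estimate means an expected step of a 1.1-fold higher number from compound 3 to compound 4 (0.06 log units; within the scatter), which is expected to remain within the scatter.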

Compound 4, half-maximal inhibitory concentration: 8690 nM
Estimate against measurement, compound 4: 5.8-fold (0.76 log units) above; the measured number lies below the stated range.
By their numbers in this assay, from the lowest: compound 4; then compounds 2, 3 and 1 (each within the scatter of the next, the first and the last beyond it).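

In this assay this aromatic carbon of the triazole turns out to tolerate real change, which the first three compounds, lying close together, had given little sign of: the replacement of cyclopropyl shows a 5.1-fold lower number from compound 3 to compound 4 (0.70 log units; beyond the scatter) and stands well clear of the earlier spread. The gain also holds against the open-chain group, with a 3.3-fold lower number from compound 2 to compound 4 (0.52 log units; beyond the scatter) in that comparison, so compound 4 is the strongest inhibitor of the four, its steps to all the others lying beyond the scatter. A six-membered aromatic ring alone does not bring this gain, as compound 1 also has one at this place and the comparison gives a 6.9-fold lower number from compound 1 to compound 4 (0.84 log units; beyond the scatter) in favour of 4-methylphenyl over 3-hydroxyphenyl, which makes what the ring carries, or where it carries it, matter here.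

The compounds shown cannot separate the part played by the methyl group from that of its place on the ring, a question that a plain phenyl group, a 4-methoxyphenyl group or a 4-aminophenyl group at this carbon would bear on. No measurement given here explains why compound 4 stands apart from the other three.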